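Nitro to (carboxymethyl)amino on a shared core

The source may hold more compounds than are shown below. What is called first, only, known or untested is meant among the compounds shown, and "the series" means these compounds.

Of the compounds shown here, three built on one core have been measured in an assay for inhibition of Indoleamine 2,3-dioxygenase 1 (Homo sapiens), with stated times of 10 min and 60 min, tested at 100 uM; on this read-out lower numbers stand for a weaker effect and higher numbers for a stronger effect at the one concentration tested. Compound 1 `Nc1cccc(CNc2cc(C(F)(F)F)cc3[nH]ncc23)c1` carries an amino group, and in this assay compound 1 gives 55%. Compound 2 `O=[N+]([O-])c1ccc(Cl)cc1CNc1cc(C(F)(F)F)cc2[nH]ncc12` carries a nitro group together with a chlorine, and in this assay compound 2 gives 65%. Compound 3 `O=[N+]([O-])c1cccc(CNc2cc(C(F)(F)F)cc3[nH]ncc23)c1` carries a nitro group alone, and in this assay compound 3 gives 69%, the largest number of the three, though its gap to compound 2 lies within the scatter, while the step of a number 14 percentage points higher from compound 1 to compound 3 (beyond the scatter) lies beyond it.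

Compound 4 `O=C(O)CNc1cccc(CNc2cc(C(F)(F)F)cc3[nH]ncc23)c1` is the next member. Relative to compound 3 the change is (carboxymethyl)amino in place of nitro on an aromatic carbon.

Within the data shown here, one measured step bears on this change: a number 14 percentage points higher from compound 1 to compound 3 (beyond the scatter), in which an amino group gave way to a nitro group. Among the measured compounds shown here, compound 4 moves the other way, giving up the nitro group for (carboxymethyl)amino, so a modest fall is expected rather than a rise, although the carboxymethyl part has no counterpart among the measured compounds and widens the uncertainty. The expected step is a number 19 percentage points lower from compound 3 to compound 4 (beyond the scatter). Compound 4 is therefore estimated at 50%, with a range from 30% to 68%.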

Compound 4, a percentage reported as inhibition, at one concentration (the size of the read-out at that concentration, not a potency): 8%
Beside the measured number, compound 4's estimate is 42 percentage points above it, and the stated range ends above it.
By their numbers in this assay, from the lowest: compound 4; then compounds 1, 2 and 3 (each within the scatter of the next, the first and the last beyond it).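

In this assay, among these compounds, exchanging nitro for (carboxymethyl)amino on this aromatic carbon gives a number 61 percentage points lower from compound 3 to compound 4 (beyond the scatter) and is a large step, whereas the only change at this place seen earlier, between amino and nitro, was modest. Adding carboxymethyl in place of hydrogen on the nitrogen gives a number 47 percentage points lower from compound 1 to compound 4 (beyond the scatter) and is also large, so losing the nitro group does not by itself account for the low number: compound 1 has no nitro group either and still gives 55% in this read-out. The compounds shown therefore place the fall with the carboxymethyl part on that nitrogen, but no measurement here offers an explanation for it.

The compounds shown leave open whether the fall follows the carboxylic acid itself or simply the added chain, as neither a methyl ester, a primary amide nor a plain ethyl group on that nitrogen stands among them. Also open, on these data alone, is how a longer chain ending in a carboxylic acid, or a carboxylic acid attached directly to the aromatic ring, would read in this assay on the shared core.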